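A few compounds are considered here, and "the series" means these few. Any claim that something is new, unique, unknown or untested is made for them only; others in the source may bear on it.

Notes on the series. In a functional assay on MCF7 cells (Homo sapiens) for cytotoxicity, read by MTT assay, with a stated time of 96 h (a lower number here means a stronger inhibitor, a higher number a weaker inhibitor), compound 1 `COc1cc(C(=O)c2cn(-c3cccc(Cl)c3)cc2-c2ccccc2)cc(OC)c1OC` gives 150 nM. Compound 2 `COc1cc(C(=O)c2cn(-c3cccc([N+](=O)[O-])c3)cc2-c2ccccc2)cc(OC)c1OC` carries the change nitro in place of chloro on an aromatic carbon and in this assay compound 2 gives 550 nM; the step is a 3.7-fold higher number from compound 1 to compound 2 (0.56 log units; beyond the scatter). Compound 3 `COc1cc(C(=O)c2cn(-c3ccc(F)cc3)cc2-c2ccccc2Cl)cc(OC)c1OC` has a different core; how its core differs from that of compound 1 is not broken down here. In this assay compound 3 gives 83 nM, within the scatter of compound 1 and beyond the scatter of compound 2.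

Compound 4 `COc1cc(C(=O)c2cn(-c3ccc(F)cc3)cc2-c2ccccc2[N+](=O)[O-])cc(OC)c1OC` is not yet measured. It differs from compound 3 by nitro in place of chloro on an aromatic carbon. The place is not the same as in the earlier pair: there the nitro sits meta to a large group, here ortho to a large group, so this is the same kind of change, not the same change. The expected step from compound 3 to compound 4 is a 3.6-fold higher number from compound 3 to compound 4 (0.56 log units; beyond the scatter), judged beside a 3.7-fold higher number from compound 1 to compound 2 (0.56 log units; beyond the scatter), the only measured occurrence of this kind of change. Compound 4 is therefore estimated at 300 nM in this assay, with a range of 100 nM to 900 nM.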

Compound 4, half-maximal inhibitory concentration: 38 nM
For compound 4 the middle estimate is 7.9-fold (0.90 log units) above the measured one; the measured number lies below the stated range.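

In this assay, the change from 2-chlorophenyl to 2-nitrophenyl gives a 2.2-fold lower number from compound 3 to compound 4 (0.34 log units; beyond the scatter), opposite in direction to the step in the earlier pair. Nitro in place of chloro on an aromatic carbon therefore cannot be carried from one core to the other in this series as a fixed step: the same change on two cores in this assay, a 3.7-fold higher number (0.56 log units; beyond the scatter) from compound 1 to compound 2 and a 2.2-fold lower number (0.34 log units; beyond the scatter) from compound 3 to compound 4, 8.0-fold (0.90 log units) apart, beyond the scatter of two such steps

This does not show why the two steps part. The two pairs differ both in the place of the change and in the rest of the core, and with a single pair on each side these two differences cannot be separated, nor does the result set a rule for any other core.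

Still open, as far as these compounds go, is whether chloro and nitro would keep the same order if the two places were compared on one shared core. Also open, from the compounds shown here alone, is how an amine or a carboxylic acid, ortho to a large group on this core, would stand against compound 3 and compound 4.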